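One Aromatic Group Exchanged on a Shared Core

This account rests on a few compounds, and the source may have more. Where it says the series, first, only, none or still open, it means among the compounds named here.

Values so far in a physicochemical assay for solubility, in phosphate buffer, at pH 7.4; a higher number here means a more soluble compound, a lower number a less soluble compound
Compound 1 `COc1cc(F)ccc1-c1ccnc2[nH]c(C3CCN(CC(=O)N(C)C)CC3)cc12` gives 38000 nM
Compound 2 `CN(C)C(=O)CN1CCC(c2cc3c(-c4ccc(=O)n(C5CCOCC5)c4)ccnc3[nH]2)CC1` gives 840000 nM
Compound 3 `CC(C)n1cc(-c2ccnc3[nH]c(C4CCN(CC(=O)N5CCCCC5)CC4)cc23)ccc1=O` gives 79000 nM

Compound 1 has the lowest number of the three, and compound 3 and compound 2 both stand higher, beyond the usual scatter. Compound 4 `CC(C)n1cc(-c2ccnc3[nH]c(C4CCN(CC(=O)N(C)C)CC4)cc23)ccc1=O` keeps the rest of compound 1 and changes only the group on an aromatic carbon opposite the ring nitrogen a group of 10 heavy atoms (8 carbon, 1 nitrogen, 1 oxygen; one six-membered aromatic ring with 1 hetero atom) in place of a group of 9 heavy atoms (7 carbon, 1 oxygen, 1 fluorine; one six-membered aromatic ring of carbon only), on an aromatic carbon where the 4-fluoro-2-methoxyphenyl stood. Among the compounds with values here, no measured pair differs in one place only, so the size of this step must be inferred. Compound 3 at 79000 nM and compound 2 at 840000 nM both carry a six-membered aromatic ring with 1 hetero atom there. An upward step beyond the scatter is expected in this assay a 7.9-fold higher number from compound 1 to compound 4 (0.90 log units; beyond the scatter) for this change. Compound 4 is estimated at 300000 nM with an expected range from 110000 nM to 800000 nM.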

Compound 4, solubility: 110000 nM
Compound 4: middle estimate off by 2.7-fold (0.44 log units), on the high side; the range from low to high includes it.
By their numbers in this assay, from the lowest: compound 1; then compounds 3 and 4 (each within the scatter of the next); then compound 2.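

In this assay, placing the group with a six-membered aromatic ring with 1 hetero atom where the 4-fluoro-2-methoxyphenyl stood, on the aromatic carbon opposite the ring nitrogen, now has a measured size (a 2.9-fold higher number from compound 1 to compound 4 (0.46 log units; beyond the scatter)). Two further single changes can also be read: dimethylamino in place of piperidin-1-yl on the carbonyl carbon (a 1.4-fold higher number from compound 3 to compound 4 (0.14 log units; within the scatter)), and isopropyl in place of oxan-4-yl on the aromatic nitrogen (a 7.6-fold lower number from compound 2 to compound 4 (0.88 log units; beyond the scatter)). No measured evidence accounts for these steps. Going by these compounds, how an amine or a carboxylic acid on that aromatic nitrogen would compare with isopropyl and oxan-4-yl remains open.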